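A Methoxy Shift Repeated on a Second Core

The compounds below may be only part of what the source reports. "The series", "measured", "known", "first", "only" and "open" are said of these compounds alone.

Three compounds built on a shared core, each carrying two methoxyphenyl groups, have been tested for how strongly they damage skin fibroblast cells. Compound 1 `COc1ccccc1/C=C1\CCC/C(=C\c2cccc(OC)c2OC)C1=O`, compound 2 `COc1cccc(/C=C2\CCC/C(=C\c3cccc(OC)c3OC)C2=O)c1` and compound 3 `COc1ccccc1/C=C1\CCC/C(=C\c2ccc(OC)c(OC)c2)C1=O` were run in an ADME assay on NHDF cells (Homo sapiens) for cytotoxicity, read by MTT assay, with a stated time of 72 h; on this read-out higher numbers stand for weaker inhibition and lower numbers for stronger inhibition. In this assay compound 1 gives 31300 nM, compound 2 gives 16400 nM and compound 3 gives 18100 nM. Compound 2 differs from compound 1 by 3-methoxyphenyl in place of 2-methoxyphenyl on a double-bonded chain carbon bound to a double-bonded ring carbon, and that change made the step of a 1.9-fold lower number from compound 1 to compound 2 (0.28 log units; within the scatter), so the two values lie close together. How the core of compound 3 differs from the core of compound 1 is not broken down here; the values of compound 3 and compound 1 also sit within the usual spread of one another.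

Compound 4 `COc1cccc(/C=C2\CCC/C(=C\c3ccc(OC)c(OC)c3)C2=O)c1` is not yet measured. It differs from compound 3 by 3-methoxyphenyl in place of 2-methoxyphenyl on a double-bonded chain carbon bound to a double-bonded ring carbon. For the measured compounds named here, this is the same change, at the same place, as the one from compound 1 to compound 2. The expectation for compound 4 therefore rests on compound 1 and compound 2, whose step a 1.9-fold lower number from compound 1 to compound 2 (0.28 log units; within the scatter) stayed within the usual scatter. In this assay compound 4 is expected to give about 11000 nM, with a likely range from 5500 nM to 22000 nM. That estimate corresponds to an expected step of a 1.6-fold lower number from compound 3 to compound 4 (0.22 log units; within the scatter), matching the earlier one in direction and size.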

Compound 4, half-maximal inhibitory concentration: 11600 nM
Estimate against measurement, compound 4: 1.1-fold (0.02 log units) below; the range from low to high includes it.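

On the core of compound 3, putting 3-methoxyphenyl in place of 2-methoxyphenyl gives, in this assay, a 1.6-fold lower number from compound 3 to compound 4 (0.19 log units; within the scatter). Set beside the same change on the core of compound 1, the two steps do not differ in any way that can be told apart: the same change on two cores in this assay, a 1.9-fold lower number (0.28 log units; within the scatter) from compound 1 to compound 2 and a 1.6-fold lower number (0.19 log units; within the scatter) from compound 3 to compound 4, 1.2-fold (0.09 log units) apart, within the scatter of two such steps This shows that, on these two cores, the swap behaves alike and the step seen on one core served as a fair guide to the other, but it does not show that the swap really alters the damage to these cells, since each step on its own stays within the ordinary spread of repeated measurements, and two cores are too few to support a rule for other cores in the series.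

The compounds shown carry only methoxy groups on their phenyl rings, so it remains open whether the same swap would behave alike if the other phenyl ring bore a hydroxyl group, an amine or a carboxylic acid instead. Going by these compounds, it is also open whether a group of a different kind in place of the moving methoxyphenyl, such as a chlorophenyl or a pyridine ring, would produce a step clearly beyond that spread.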